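Swapping an aryloxy group for a benzyl on the shared core

The source may hold more compounds than are shown below. What is called first, only, known or untested is meant among the compounds shown, and "the series" means these compounds.

Measured compounds:
- compound 1 `COc1ccccc1Oc1ccc2c(NCCCNCc3ccco3)ccnc2c1`: 9.28 in a physicochemical assay for acid dissociation
- compound 2 `COc1ccc(Oc2ccc3c(NCCCNCc4cc(F)ccc4OC)ccnc3c2)cc1`: 9.28 in this assay
- compound 3 `COc1ccc(F)cc1CNCCCNc1ccnc2cc(CCC(C)C)ccc12`: 9.47 in this assay

Compound 1 stands level with compound 2 at the digits shown, and the two together are the lowest of the three numbers in this assay; compound 3 lies only a number 0.19 log units higher from compound 2 to compound 3 (within the scatter) away from compound 2, a gap within the scatter, so no ordering among the three can be claimed. The unmeasured compound 4 `Cc1cc(C)cc(Cc2ccc3c(NCCCNCc4ccco4)ccnc3c2)c1` differs from compound 1 in one place: 3,5-dimethylbenzyl in place of 2-methoxyphenoxy on an aromatic carbon. Among the measured compounds shown here, the single step that bears on this is the one from compound 2 to compound 3, in which a methoxyphenoxy group on the same part of the core gives way to a plain hydrocarbon group, isopentyl, and the read-out moved by a number 0.19 log units higher from compound 2 to compound 3 (within the scatter), within the scatter. The present change likewise puts a hydrocarbon group, 3,5-dimethylbenzyl, where 2-methoxyphenoxy sat, so no step beyond the scatter is expected in this assay. Compound 4 is therefore estimated at 9.35, between 9 and 9.7, which means an expected step of a number 0.07 log units higher from compound 1 to compound 4 (within the scatter).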

Compound 4, acid dissociation constant: 9.47
The estimate for compound 4 lay 0.12 log units below the measured number, and the stated range covers the measured number.
By their numbers in this assay, from the lowest: compounds 1, 2, 3 and 4 (each within the scatter of the next).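

In this assay the exchange of 2-methoxyphenoxy for 3,5-dimethylbenzyl gives a number 0.19 log units higher from compound 1 to compound 4 (within the scatter) and so provides a second pair of compounds, with a different amine side chain from the first pair, in which a change on this aromatic carbon stays inside the scatter. Unlike isopentyl, the entering group keeps the six-membered aromatic ring of carbon only and the heavy-atom count of the group it replaces, while the oxygen atoms and hydrogen-bond acceptors of that group are lost, and the read-out still shows no step beyond the scatter. Nothing at hand gives a reason for this result.

Still open, going by these compounds, is whether any group on this aromatic carbon moves the read-out beyond the scatter, for instance an amine, a carboxylic acid or a longer chain.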